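A few compounds are considered here, and "the series" means these few. Any claim that something is new, unique, unknown or untested is made for them only; others in the source may bear on it.

Three compounds share one core, a coumarin-like ring bearing a methoxy group and an ether-linked chain that ends in a furoxan ring. Compound 1 `COc1cc2ccc(=O)oc2cc1OCCOc1no[n+]([O-])c1S(=O)(=O)c1ccccc1`, compound 2 `COc1cc2ccc(=O)oc2cc1OCCCOc1no[n+]([O-])c1S(=O)(=O)c1ccccc1` and compound 3 `COc1cc2ccc(=O)oc2cc1OCCCCCOc1c[n+]([O-])on1` have all been tested in a functional assay on A549 cells (Homo sapiens) for inhibition, read by MTT assay, with a stated time of 48 h; a lower number here means a stronger inhibitor, a higher number a weaker inhibitor. In this assay compound 3 gives 10600 nM, a number that sits within the usual scatter of compound 1 at 7240 nM and also within the scatter of compound 2 at 5450 nM, so none of the three can be set apart from the others on these figures.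

Compound 4 `COc1cc2ccc(=O)oc2cc1OCCCCCCOc1c[n+]([O-])on1` differs from compound 3 only in the length of the chain: a group of 8 heavy atoms (3 carbon, 2 nitrogen, 3 oxygen; one five-membered aromatic ring with 3 hetero atoms) in place of a group of 7 heavy atoms (2 carbon, 2 nitrogen, 3 oxygen; one five-membered aromatic ring with 3 hetero atoms), on a saturated chain carbon, five bonds along the chain from an oxygen on an aromatic ring. Going by the values given here, no pair among the measured compounds reports this single change, so there is no measured step to lean on. With compound 3 at 10600 nM as the anchor and the change limited to one added chain carbon, the step of a 1.1-fold lower number from compound 3 to compound 4 (0.05 log units; within the scatter) is expected to stay within the scatter, in no particular direction. In this assay compound 4 is therefore estimated at 9500 nM, with a likely range from 4000 nM to 22000 nM.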

Compound 4, half-maximal inhibitory concentration: 9430 nM
Compound 4: the middle estimate sits 1.0-fold (0.00 log units) above what was measured; measured number inside the range.
By their numbers in this assay, from the lowest: compounds 2, 1, 4 and 3 (each within the scatter of the next).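

In this assay, going by these compounds alone, the step of a 1.1-fold lower number from compound 3 to compound 4 (0.05 log units; within the scatter) is the first measured single change in this set, since no two earlier compounds differ in one place only. It shows that the larger group of 8 heavy atoms, in place of the group of 7 heavy atoms on a saturated chain carbon, five bonds along the chain from an oxygen on an aromatic ring, leaves the number within the scatter; this holds for this one pair only. Nothing available here bears on what lies behind this result.

From the compounds shown here alone, whether a longer chain, or an amine at the end of the chain, would move the number beyond the scatter remains open. Compounds 1 and 2 differ from compound 3 and compound 4 in more than one place, so those steps cannot be read.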